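Swapping a Sugar for a Pyridine at the Oxime Ether

This account rests on a few compounds, and the source may have more. Where it says the series, first, only, none or still open, it means among the compounds named here.

The measured compounds:
compound 1 `OC1O[C@H](CO/N=C2\CCc3cc(Sc4cc(F)cc(C5CCOCC5)c4)ccc32)[C@H](O)[C@H](O)[C@H]1O` — 81000 nM
compound 2 `CO[C@]1(c2cc(F)cc(S(=O)(=O)c3ccc(/C(C)=N/O)cc3)c2)CCO[C@@H](C)C1` — 4600 nM
compound 3 `CO[C@]1(c2cnc(S(=O)(=O)c3ccc(/C(C)=N/OCC#N)cc3)s2)CCO[C@@H](C)C1` — 1000 nM

In a physicochemical assay for solubility (on this read-out higher numbers stand for higher solubility and lower numbers for lower solubility), compound 1 gives 81000 nM, the highest of the three numbers. The nearest is compound 2, which gives 4600 nM, a gap beyond the scatter. Compound 3, furthest away, gives 1000 nM, also beyond the scatter. Compounds 2 and 3 differ from compound 1 in several places at once, so their values say only where they stand, not what any single change does.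

Compound 4 `Fc1cc(Sc2ccc3c(c2)CC/C3=N\OCc2ccncc2)cc(C2CCOCC2)c1` is the next step from compound 1. The change is pyridin-4-yl in place of 3,4,5,6-tetrahydroxyoxan-2-yl on a saturated chain carbon bound to an oxygen on an unsaturated carbon. Among the measured compounds shown here, no measured pair shows a single change of this kind, so there is no step in this assay to lean on directly. Even so, compound 4 is expected to come out lower than compound 1, with a step of a 41-fold lower number from compound 1 to compound 4 (1.61 log units; beyond the scatter) in this assay, well beyond the scatter. The estimate for compound 4 is 2000 nM, within a range from 300 nM to 15000 nM.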

Compound 4, solubility: 100000 nM
Beside the measured number, compound 4's estimate is 50-fold (1.70 log units) below it; the measured number lies above the stated range.
By their numbers in this assay, from the lowest: compound 3; then compound 2; then compounds 1 and 4 (each within the scatter of the next).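

The step in this assay is a 1.2-fold higher number from compound 1 to compound 4 (0.09 log units; within the scatter) and so, on a saturated chain carbon bound to an oxygen on an unsaturated carbon, pyridin-4-yl and 3,4,5,6-tetrahydroxyoxan-2-yl cannot be told apart on this read-out. Among the compounds shown here, this pair is the first in the set that differs in one place only, and it shows that replacing a group of 10 heavy atoms and 4 hydrogen-bond donors with one of 6 heavy atoms and 0 donors left the number within the scatter here. Nothing available accounts for this match.

The compounds shown leave open whether other groups at this place would also match, such as a plain methyl, a carboxylic acid or a dimethylamino chain. They also leave open whether the match would hold on the cores of compound 2 and compound 3.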